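The source may hold more compounds than are shown below. What is called first, only, known or untested is meant among the compounds shown, and "the series" means these compounds.

Measured compounds:
Compound 1 `CC1(C)[C@H](c2c[nH]cn2)[C@H]1c1cccc2c1CCO2`: in a functional assay on AP1 cells for inhibition of sodium/hydrogen exchanger 1 (Homo sapiens) (on this read-out lower numbers stand for stronger inhibition and higher numbers for weaker inhibition), compound 1 gives > 30000 nM, a limit of the assay.
Compound 2 `CC1(C)[C@H](c2cnc(N)s2)[C@H]1c1cccc2c1CCO2`: in this assay compound 2 gives > 30000 nM, a limit of the assay.
Compound 3 `CC1(C)[C@H](c2cc(Cl)cc(Cl)c2)[C@H]1c1c[nH]cn1`: in this assay compound 3 gives 4000 nM.

For the measured compounds named here, compound 3 holds the only number among the three; the two other values sit at the limit of > 30000 nM in this assay, at which 2 of the 3 values shown sit. Compound 4 `CC1(C)[C@H](c2cc(Cl)cc(Cl)c2)[C@H]1c1cnc(N)s1` carries the change (2-amino-1,3-thiazol-5-yl in place of 1H-imidazol-4-yl on a saturated ring carbon). Going by the values given here, the one measured step of the same kind, a step that the two limits leave unreadable from compound 1 to compound 2, lies between two limits and shows no size, so it gives no readable guidance for the step in this assay. The expectation therefore rests on compound 3 alone, with a wide range in both directions. Compound 4 is expected to reach about 6000 nM, between 1500 nM and 30000 nM, which means an expected step of a 1.5-fold higher number from compound 3 to compound 4 (0.18 log units; within the scatter).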

Compound 4, half-maximal inhibitory concentration: > 30000 nM
Compound 4: a limit, no number; the forecaster's own chance of this, stated with the estimate: 30%; middle value at least 5.0-fold (0.69 log units) from the limit.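

In this assay, 2-amino-1,3-thiazol-5-yl in place of 1H-imidazol-4-yl on a saturated ring carbon gives an at least 7.5-fold higher number from compound 3 to compound 4 (0.87 log units; beyond the scatter), the first readable size for this change. The same change between compound 1 and compound 2 cannot be read. Compound 4 gives > 30000 nM, which is a limit of the assay, and it joins the other limits of the set: the limit of > 30000 nM in this assay, at which 3 of the 4 values shown sit.

From the compounds shown here alone, how far compound 4 lies past that limit stays open. Also open, going by these compounds, is whether an aminomethyl group or a carboxylic acid on the same saturated ring carbon would give a number in this assay.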